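The compounds below may be only part of what the source reports. "The series", "measured", "known", "first", "only" and "open" are said of these compounds alone.

Of the compounds shown here, three have so far been tested in an ADME assay on Huh-7 cells (Homo sapiens) for cytotoxicity; a lower number here means that less compound is tolerated, a higher number that more compound is tolerated. Compound 1, `CN1CCN(CCCNCc2cn(-c3ccc([N+](=O)[O-])cc3)nc2-c2ccc(OC(F)(F)F)cc2)CC1`, gives 1600 nM in this assay and is the only one of the three for which a number, rather than a limit, is available. Compound 2, `Cc1ccccc1-c1nn(-c2ccc(F)cc2F)cc1CNCCN1CCCCC1`, reaches only a limit of the assay, reported as > 20000 nM. Compound 3, `Cc1ccccc1CNc1nn(-c2ccc(F)cc2F)cc1CNCCN1CCN(C)CC1`, likewise reaches only a limit of the assay, reported as > 20000 nM. The wider picture of these values is summed up by the limit of > 20000 nM in this assay, at which 2 of the 3 values shown sit, so compound 1 stands alone as the measured point from which any next step is judged.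

Compound 4, `CN1CCN(CCCNCc2cn(-c3ccc([N+](=O)[O-])cc3)nc2-c2ccc(Cl)cc2)CC1`, differs from compound 1 in one place: chloro in place of trifluoromethoxy on an aromatic carbon. Among the compounds with values here, no pair of measured compounds separated by this single change exists here, so the size of the step cannot be read from the data. The expectation is that the step from compound 1 to compound 4 stays within the usual scatter, with no clear direction, which is an estimated 1.3-fold higher number from compound 1 to compound 4 (0.10 log units; within the scatter). Compound 4 is therefore expected to give about 2000 nM in this assay, most likely between 700 nM and 6000 nM.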

Compound 4, half-maximal cytotoxic concentration: 3700 nM
For compound 4 the middle estimate is 1.9-fold (0.27 log units) below the measured one, and the stated range covers the measured number.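

Within the data shown here, replacing trifluoromethoxy with chloro on this aromatic carbon gives the first reading of this position in this assay, with a 2.3-fold higher number from compound 1 to compound 4 (0.36 log units; beyond the scatter). The group at this place therefore has a measurable, if modest, bearing on how much compound the cells tolerate, and in this one pair the chloro, with one heavy atom against five, goes with the higher number. Compound 4, like compound 1, still gives a number rather than a limit, in a small set with a clear upper end: the limit of > 20000 nM in this assay, at which 2 of the 4 values shown sit.

A single pair cannot tell which difference between the two groups matters, and the step may not carry over to other compounds. Going by these compounds, how a methoxy group, an amine or a carboxylic acid at this same place would compare remains open.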